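Removing the Methyl from a Weak Quinolinone-Type Inhibitor

This account rests on a few compounds, and the source may have more. Where it says the series, first, only, none or still open, it means among the compounds named here.

Measured compounds:
Compound 1 `Cc1ccc2[nH]c(=O)c(/C=N/c3ccc(O)cc3)cc2c1` gives 88500 nM in a functional assay, read by spectrophotometry, with a stated time of 30 min; a lower number here means a stronger inhibitor, a higher number a weaker inhibitor.
Compound 2 `Cc1ccc2[nH]c(=O)c(/C=N/Nc3ccc([N+](=O)[O-])cc3)cc2c1` gives 109000 nM in this assay.

Both compounds share the same core and are weak inhibitors. In this assay compound 2 gives 109000 nM, while compound 1 gives 88500 nM in this assay; the two numbers lie within the usual scatter of repeated measurements, so neither can be called the stronger of the pair. For the measured compounds named here, no step between measured compounds is available to show how a change on the core affects the numbers.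

Compound 3 `O=c1[nH]c2ccccc2cc1/C=N/Nc1ccc([N+](=O)[O-])cc1` has not yet been measured. It differs from compound 2 in one place: hydrogen in place of methyl on an aromatic carbon. In words, a hydrogen takes the place of the methyl on an aromatic carbon of the shared core. With nothing measured to show what this small change does, no step beyond the scatter is expected, though the number may edge upward. The expected step of a 1.2-fold higher number from compound 2 to compound 3 (0.08 log units; within the scatter) is therefore small. For compound 3 the estimate in this assay is 130000 nM, with a range from 50000 nM to 350000 nM.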

Compound 3, half-maximal inhibitory concentration: 170000 nM
Compound 3: the middle estimate sits 1.3-fold (0.12 log units) below what was measured; measured number inside the range.
By their numbers in this assay, from the lowest: compounds 1, 2 and 3 (each within the scatter of the next).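

For the compounds shown here, this is the first step on the shared core that can be read at a single place. In this assay, hydrogen in place of methyl on an aromatic carbon gives a 1.6-fold higher number from compound 2 to compound 3 (0.19 log units; within the scatter), so at this place, meta to a fused ring and para to a fused ring, the data do not show that the methyl matters in either direction. Nothing in the data offers an explanation for this small step.

Still open, going by these compounds, is whether another group on this same aromatic carbon, such as an ethyl, a methoxy, an amine or a chlorine atom, would shift the number by more than the usual scatter of repeated measurements. Also open, on these data alone, is whether the same exchange of methyl for hydrogen on compound 1 would give a similarly small step.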